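Two configurations of a hydroxy amide enoate on cells

A few compounds are considered here, and "the series" means these few. Any claim that something is new, unique, unknown or untested is made for them only; others in the source may bear on it.

Measured compounds:
compound 1, `COC(=O)/C=C\NC(=O)[C@H](O)C(C)(C)CO` — "not determined" (no result reported)
compound 2, `CC(C)(C)OC(=O)/C=C\NC(=O)[C@H](O)C(C)(C)CO` — -9%

Compound 1 carries a methyl ester, and compound 2 the tert-butyl ester of the same acid. In an ADME assay on HEK293 cells (Homo sapiens) for inhibition, read by CellTiter-Glo, with a stated time of 96 h, tested at 100 uM (a lower number here means less inhibition, a higher number more inhibition at the concentration tested (going by the name of the read-out)), compound 2 gives -9%, a reading that sits within the usual scatter around no inhibition at all. For compound 1 this assay reports "not determined" (no result reported), so compound 1 stands nowhere on the numbers: it has no value of its own to compare with compound 2.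

Compound 3, `COC(=O)/C=C/NC(=O)[C@@H](O)C(C)(C)CO`, keeps every atom and bond of compound 1 and differs only in configuration: the two compounds have the same atoms and bonds and differ only in configuration as drawn: 2 of 2 stereo elements differ; a stereocentre at a saturated chain carbon is drawn R in compound 1 and S in compound 3; a double bond is drawn Z in compound 1 and E in compound 3. Within the data shown here, since no measured pair shows what such a change does in this assay, the step from compound 1 to compound 3 is expected to be none beyond the scatter, in either direction, given that compound 2 gives -9%, a number that sits low in this assay. Compound 3 is therefore estimated at 0%, with a range from -15% to 15%.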

Compound 3, a percentage reported as inhibition, at one concentration (the size of the read-out at that concentration, not a potency): -2%
Compound 3: the middle estimate sits 2 percentage points above what was measured, and the stated range covers the measured number.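

With no number for compound 1 in this assay, no step to compound 3 can be read, though the pair is closely matched: the fact that compounds 1 and 3 differ only in the configuration as drawn

The compounds shown leave open whether the configuration at the stereocentre or the double bond alters the reading in this assay.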